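From 4-fluorophenyl to 3-chlorophenyl on the shared core

This account rests on a few compounds, and the source may have more. Where it says the series, first, only, none or still open, it means among the compounds named here.

In a functional assay on LoVo cells (Homo sapiens) for inhibition, read by MTT assay, with a stated time of 24 h (a lower number here means a stronger inhibitor, a higher number a weaker inhibitor), compound 3 `CC1(C)[C@H]2CC[C@]1(C)N(Cc1cn(-c3ccc(F)cc3)nn1)C(=O)C2` gives 40 nM, level within the scatter with compound 1 `CC1(C)[C@H]2CC[C@]1(C)N(Cc1cn(-c3ccccc3Br)nn1)C(=O)C2` at 60 nM. Compound 2 `CC1(C)[C@H]2CC[C@]1(C)N(Cc1cn(-c3cccc(C#N)c3)nn1)C(=O)C2` is clearly weaker at 320 nM. That gap reads an 8.0-fold lower number from compound 2 to compound 3 (0.90 log units; beyond the scatter).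

Compound 4 `CC1(C)[C@H]2CC[C@]1(C)N(Cc1cn(-c3cccc(Cl)c3)nn1)C(=O)C2` differs from compound 3 by 3-chlorophenyl in place of 4-fluorophenyl on an aromatic nitrogen. Two earlier steps bear on this. Exchanging one halogen-bearing phenyl for another changed little, a 1.5-fold lower number from compound 1 to compound 3 (0.18 log units; within the scatter), while moving to 3-cyanophenyl mattered more, a 5.3-fold higher number from compound 1 to compound 2 (0.73 log units; beyond the scatter). Chlorine is a halogen, so the first step is the closer guide, and the second warns of some loss.

The expected change in this assay is small and upward, a 2.3-fold higher number from compound 3 to compound 4 (0.35 log units; beyond the scatter). Compound 4 is estimated at 90 nM, with an expected range of 30 nM to 280 nM.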

Compound 4, half-maximal inhibitory concentration: 70 nM
Compound 4: middle estimate off by 1.3-fold (0.11 log units), on the high side; the range from low to high includes it.
By their numbers in this assay, from the lowest: compounds 3, 1 and 4 (each within the scatter of the next); then compound 2.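

In this assay, the 3-chlorophenyl group reads level with the other two halogen-bearing phenyl groups: both a 1.8-fold higher number from compound 3 to compound 4 (0.24 log units; within the scatter) and a 1.2-fold higher number from compound 1 to compound 4 (0.07 log units; within the scatter) stay within the scatter. Chloro in place of cyano, the only change between this pair, gives a 4.6-fold lower number from compound 2 to compound 4 (0.66 log units; beyond the scatter) and so ties the weaker number of compound 2 to the cyano group, not to any group at that place on the phenyl. Nothing available here explains these numbers. As far as these compounds go, whether an amine or a carboxylic acid on the phenyl would hold this level remains open.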